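Acylurea thiazole hydrazones: varying the benzoyl aryl

The compounds below may be only part of what the source reports. "The series", "measured", "known", "first", "only" and "open" are said of these compounds alone.

Compound 1 `CN(C(=O)NC(=O)c1ccc(F)c(F)c1)c1nc(C(F)(F)F)c(C(=O)N/N=C/c2ccc(C(F)(F)F)cc2)s1` gives 6.26 ug/mL in a functional assay on HepG2 cells (Homo sapiens) for inhibition, read by MTT assay, with a stated time of 72 h; on this read-out lower numbers stand for stronger inhibition and higher numbers for weaker inhibition.
Compound 3 `CN(C(=O)NC(=O)c1ccc(F)c(F)c1)c1nc(C(F)(F)F)c(C(=O)N/N=C/c2ccccc2C(F)(F)F)s1` gives 10.4 ug/mL in this assay.
Compound 2 `CNc1nc(C)c(C(=O)N/N=C/c2cc(C(F)(F)F)cc(C(F)(F)F)c2)s1` reaches only a limit, > 100 ug/mL in this assay.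

Compound 1 holds the lowest of the two numbers shown, and the nearest one, from compound 3, is a 1.7-fold higher number from compound 1 to compound 3 (0.22 log units; within the scatter). Compound 4 `CN(C(=O)NC(=O)c1ccc(C(F)(F)F)cc1)c1nc(C(F)(F)F)c(C(=O)N/N=C/c2ccc(C(F)(F)F)cc2)s1` differs from compound 1 by 4-(trifluoromethyl)phenyl in place of 3,4-difluorophenyl on a carbonyl carbon. No measured step touches that carbonyl aryl; the only step shown, a 1.7-fold higher number from compound 1 to compound 3 (0.22 log units; within the scatter), concerns the aryl on the carbon with a double bond to nitrogen and stayed within the scatter. Compound 4 is therefore expected to give 7 ug/mL, with a range from 2.5 ug/mL to 20 ug/mL. The estimated step of a 1.1-fold higher number from compound 1 to compound 4 (0.05 log units; within the scatter) is expected to lie within the scatter.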

Compound 4, half-maximal inhibitory concentration: > 100 ug/mL
Compound 4 ended at the assay's limit; the forecaster's own chance of this, stated with the estimate: 5%; middle value at least 14-fold (1.15 log units) from the limit.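

In this assay, within the data shown here, the aryl on the carbonyl carbon proves sensitive, with an at least 15-fold higher number from compound 1 to compound 4 (1.20 log units; beyond the scatter) on this one change, whereas the only earlier step, at the aryl on the carbon with a double bond to nitrogen, stayed within the scatter. Compound 4 gives > 100 ug/mL as a limit of the assay and not as a number. That limit recurs among the compounds shown: the limit of > 100 ug/mL in this assay, at which 2 of the 4 values shown sit.

As far as these compounds go, it stays open whether the loss follows the trifluoromethyl group or the absence of the two fluorines. From the compounds shown here alone, it also stays open how a 4-fluorophenyl, a 4-aminophenyl or a 4-carboxyphenyl would fare on this carbonyl carbon.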